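The source may report more compounds than this note shows. Statements on the series, on what has been measured and on what is new or still open speak of the compounds shown alone.

Measured so far:
Compound 1 `CC(CNCC1CCCC1)Oc1cccc2ccc(N)nc12` — in an assay on cells with melanin-concentrating hormone receptor 1 (Homo sapiens) as the target, read by radioligand binding (on this read-out lower numbers stand for stronger inhibition and higher numbers for weaker inhibition), compound 1 gives 100 nM.
Compound 2 `CC(CNCc1ccccc1)Oc1cccc2ccc(N)nc12` — in this assay compound 2 gives 100 nM.

Compound 2 stands level with compound 1; the step of no change at the digits printed from compound 1 to compound 2 (within the scatter) lies within the scatter. Compound 3 `CC(CNCc1ccoc1)Oc1cccc2ccc(N)nc12` differs from compound 2 by furan-3-yl in place of phenyl on a saturated chain carbon bound to an amine nitrogen. Within the data shown here, the only step bearing on this place, from compound 1 to compound 2, exchanged one ring for another there without change, so the expected step of a 1.5-fold higher number from compound 2 to compound 3 (0.18 log units; within the scatter) is small, if any. Compound 3 is estimated at 150 nM, within 50 nM to 450 nM.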

Compound 3, half-maximal inhibitory concentration: 10 nM
For compound 3 the middle estimate is 15-fold (1.18 log units) above the measured one; the whole stated range lies above it.
By their numbers in this assay, from the lowest: compound 3; then compounds 1 and 2 (each within the scatter of the next).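

At the saturated chain carbon bound to an amine nitrogen, the ring proved to matter in this assay: furan-3-yl in place of phenyl brings a 10-fold lower number from compound 2 to compound 3 (1.00 log units; beyond the scatter), and furan-3-yl in place of cyclopentyl brings a 10-fold lower number from compound 1 to compound 3 (1.00 log units; beyond the scatter). The earlier exchange of one ring for another had shown no such sensitivity at this place. Nothing at hand explains this gain.

The compounds shown leave open whether the gain depends on the ring oxygen or would persist with thiophen-3-yl. They also leave open how furan-2-yl would compare at this place.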